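Amide aryl swap on a thiophene-ester core: antiproliferative read-out

The source may report more compounds than this note shows. Statements on the series, on what has been measured and on what is new or still open speak of the compounds shown alone.

Measured compounds:
compound 1, `COC(=O)c1scc(-c2ccc(NC(=O)c3ccc(OC)nc3)cc2)c1OC`, 15300 nM
compound 2, `COC(=O)c1scc(-c2ccc(NC(=O)c3ccc4ccccc4c3)cc2)c1OC`, 5250 nM
compound 3, `COC(=O)c1scc(-c2ccc(NC(=O)c3ccc(F)c(Cl)n3)cc2)c1OC`, 10300 nM

The three measurements come from a functional assay on MDA-MB-231 cells (Homo sapiens) for antiproliferative activity, read by MTT assay, with a stated time of 24 h; on this read-out higher numbers stand for weaker inhibition and lower numbers for stronger inhibition. Compound 1 gives the highest of the three numbers. Within the data shown here, its nearest neighbour is compound 3, at a 1.5-fold lower number from compound 1 to compound 3 (0.17 log units; within the scatter); the only step that is clearly beyond the scatter is a 2.9-fold lower number from compound 1 to compound 2 (0.46 log units; beyond the scatter), while the pair compound 2 and compound 3 shows a 2.0-fold higher number from compound 2 to compound 3 (0.29 log units; within the scatter).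

Compound 4, `COC(=O)c1scc(-c2ccc(NC(=O)c3cccc(I)c3)cc2)c1OC`, is the next compound, not yet tested in this assay. Compared with compound 1 the difference is 3-iodophenyl in place of 6-methoxypyridin-3-yl on a carbonyl carbon.

Among the measured compounds shown here, two measured steps bear on this change, since both also swap the group on the carbonyl carbon of compound 1. Replacing it with a carbon-only two-ring aromatic gave the modest lowering seen in a 2.9-fold lower number from compound 1 to compound 2 (0.46 log units; beyond the scatter); replacing it with another substituted pyridine gave a 1.5-fold lower number from compound 1 to compound 3 (0.17 log units; within the scatter), which stays within the scatter. A carbon-only single ring carrying one iodine sits between these two cases, so a lowering of the number from compound 1 is expected, though smaller than that seen for compound 2 and not certain to clear the scatter.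

Compound 4 is therefore estimated at 7500 nM, with a range from 3000 nM to 18000 nM, corresponding to an expected step of a 2.0-fold lower number from compound 1 to compound 4 (0.31 log units; beyond the scatter).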

Compound 4, half-maximal inhibitory concentration: 8240 nM
Beside the measured number, compound 4's estimate is 1.1-fold (0.04 log units) below it; low and high end bracket the measured number.
By their numbers in this assay, from the lowest: compounds 2, 4, 3 and 1 (each within the scatter of the next, the first and the last beyond it).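

In this assay, the 3-iodophenyl group on the carbonyl carbon gives a 1.9-fold lower number from compound 1 to compound 4 (0.27 log units; within the scatter), so exchanging the 6-methoxypyridin-3-yl group for a ring of carbon only with 0 hydrogen-bond acceptors does not produce a step that clears the scatter. Among these compounds, the other two comparisons, a 1.3-fold lower number from compound 3 to compound 4 (0.10 log units; within the scatter) and a 1.6-fold higher number from compound 2 to compound 4 (0.20 log units; within the scatter), are also within the scatter, which leaves compound 4 unresolved from each of the other three compounds and keeps compound 1 and compound 2 as the only pair separated beyond it. Across these four compounds, a substituted pyridine, an iodinated phenyl and a naphthyl group at this position all give numbers in the micromolar range, and no measurement shown here explains the differences among them.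

The compounds shown leave open whether a group of a different kind on the carbonyl carbon, such as a saturated ring, a longer alkyl chain or an aryl ring carrying an amine or a carboxylic acid, would move the number further than any of these aromatic groups. They also leave open whether the same swaps would behave alike on a changed core, for example with a carboxylic acid in place of the methyl ester.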